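This account rests on a few compounds, and the source may have more. Where it says the series, first, only, none or still open, it means among the compounds named here.

Working notes on the series.

Compound 1 `CCCNCc1ccccc1OCCCCCC(=O)OCC` carries a (propylamino)methyl group on its core. Compound 2 `CCCNCc1cccc(OCCCCCC(=O)OCC)c1` is built from the same atoms joined differently; how the two cores differ is not broken down here. Compound 3 `CCOC(=O)CCCCCOc1ccccc1C=O` carries a formyl group on the core of compound 1, and compound 4 `CCOC(=O)CCCCCOc1cccc(C=O)c1` carries a formyl group on the core of compound 2.

In an ADME assay on HepG2 cells (Homo sapiens) for cytotoxicity, read by CellTiter-Glo and resazurin assay, with a stated time of 72 h (a lower number here means that less compound is needed, a higher number that more compound is needed for the effect), compound 1 gives only a limit of the assay, > 26000 nM. In this assay compound 2 also gives only a limit, > 26000 nM. In this assay compound 3 likewise gives only a limit, > 26000 nM. Within the data shown here, all values so far therefore sit at the limit of > 26000 nM in this assay, at which 3 of the 3 values shown sit.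

The measured change is formyl in place of (propylamino)methyl on an aromatic carbon, and it gives a step that the two limits leave unreadable from compound 1 to compound 3. The pending change is formyl in place of (propylamino)methyl on an aromatic carbon. It is the same kind of change, not the same: the place is meta to a large group here, where it was ortho to a large group before.

For compound 4 the expectation rests on compound 2 with > 26000 nM and on compound 3 with > 26000 nM. The step expected from this change is a step that the limit leaves unreadable from compound 2 to compound 4, read against the earlier one. Compound 4 is therefore expected to give 30000 nM in this assay, most probably reported only as a limit, because the limit of > 26000 nM in this assay, at which 3 of the 3 values shown sit, is where every measured value of the series lies. The expected range is taken as 15000 nM to 100000 nM.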

Compound 4, half-maximal effective concentration: > 26000 nM
Compound 4 was reported as a limit; the forecaster's own chance of this, stated with the estimate: 85%; the middle value does not contradict the limit.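

Compound 2 and compound 4 both stand only as limits in this assay, so no step can be read between them: the limit of > 26000 nM in this assay, at which 4 of the 4 values shown sit.

The compounds shown leave open at what concentration any of the four would reach the half-maximal effect in this assay, and whether exchanging (propylamino)methyl for formyl, or the difference between the two cores, shifts that concentration at all.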